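Chloro-substituted Aryl Ethers on a Shared Spirocyclic Core

The compounds below may be only part of what the source reports. "The series", "measured", "known", "first", "only" and "open" are said of these compounds alone.

Compound 1 `NC1=NC2(CCOCC2)N(OCCCOc2cccc(Cl)c2)C(N)=N1`: 150 nM
Compound 2 `NC1=NC2(CCOCC2)N(OCCCOc2ccc(F)cc2)C(N)=N1`: "not determined" (no result reported)
Compound 3 `Cc1ccc(OCCCON2C(N)=NC(N)=NC23CCOCC3)cc1`: "not determined" (no result reported)

Three compounds share the core of compound 1 and differ only in the aromatic group attached through the chain oxygen. In a functional assay on HepG2 cells (Homo sapiens) for antiproliferative activity, read by MTT assay, with a stated time of 72 h (a higher number here means a weaker inhibitor, a lower number a stronger inhibitor), compound 1 gives 150 nM. For compound 2 the result in this assay is "not determined" (no result reported), and for compound 3 the result in this assay is likewise "not determined" (no result reported), so compound 3 stands on no number at all, and nothing can be said of where it sits relative to compound 1.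

Compound 4 `NC1=NC2(CCOCC2)N(OCCCOc2cccc(Cl)c2Cl)C(N)=N1` is the next member. Compared with compound 3 the change is 2,3-dichlorophenyl in place of 4-methylphenyl on an oxygen on a saturated carbon. For the measured compounds named here, with no number for compound 3, no step in this assay can be sized or given a direction; the only anchor is compound 1, whose 3-chlorophenyl group is the closest relative of the entering group. Going by the values given here, compound 4 is therefore expected to land near compound 1 because 150 nM is the sole measured value, with an estimate of 120 nM and a range from 40 nM to 400 nM.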

Compound 4, half-maximal inhibitory concentration: 330 nM
Compound 4: middle estimate off by 2.8-fold (0.44 log units), on the low side; the measured number falls inside the stated range.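

Chloro in place of hydrogen on an aromatic carbon, which turns 3-chlorophenyl into 2,3-dichlorophenyl, gives in this assay a 2.2-fold higher number from compound 1 to compound 4 (0.34 log units; beyond the scatter), the first step on this aromatic group that can be sized. It shows that the read-out responds to this single change, with the second chlorine modestly weakening the result rather than strengthening it. The steps involving compound 2 or compound 3 cannot be read, as neither has a number, and nothing measured here bears on why the added chloro has this effect.

The compounds shown leave open how a plain phenyl or a methoxy-substituted phenyl would read in this assay. They also leave open whether a longer chain to the aromatic group would shift the result.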